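A Halogen Swap on the Aryl Ring of the Amine Nitrogen

The source may hold more compounds than are shown below. What is called first, only, known or untested is meant among the compounds shown, and "the series" means these compounds.

Of the compounds shown here, three on a shared core have been measured. Compound 1 `CCCn1c(=O)[nH]c2nc(-c3ccc(S(=O)(=O)N4CCN(c5ccc(F)cc5)CC4)cc3)[nH]c2c1=O` gives 14% in an assay on CHO cells for displacement of a labelled ligand from adenosine receptor A1 (Homo sapiens), read by scintillation counting, with a stated time of 90 min, tested at 1 uM, in the presence of a further agent that is not named here (on this read-out higher numbers stand for more inhibition at the one concentration tested (going by the name of the read-out) and lower numbers for less inhibition), the lowest of the three numbers. Compound 2 `CCCn1c(=O)[nH]c2nc(-c3ccc(S(=O)(=O)N4CCN(C(C)c5ccccc5)CC4)cc3)[nH]c2c1=O` gives 42% in this assay, and compound 3 `CCCn1c(=O)[nH]c2nc(-c3ccc(S(=O)(=O)N4CCN(c5ccc(I)cc5)CC4)cc3)[nH]c2c1=O` gives 24% in this assay. The step of a number 28 percentage points higher from compound 1 to compound 2 (beyond the scatter) comes with 1-phenylethyl in place of 4-fluorophenyl on an amine nitrogen in a ring, the step of a number 10 percentage points higher from compound 1 to compound 3 (within the scatter) with iodo in place of fluoro on an aromatic carbon, and the step of a number 18 percentage points lower from compound 2 to compound 3 (beyond the scatter) with 4-iodophenyl in place of 1-phenylethyl on an amine nitrogen in a ring.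

Compound 4 `CCCn1c(=O)[nH]c2nc(-c3ccc(S(=O)(=O)N4CCN(c5ccccc5Cl)CC4)cc3)[nH]c2c1=O` differs from compound 1 as follows: 2-chlorophenyl in place of 4-fluorophenyl on an amine nitrogen in a ring. For the measured compounds named here, the step that bears on this is the halogen exchange from compound 1 to compound 3, which stayed within the scatter; no measured compound carries a 2-chlorophenyl, so the 1-phenylethyl step gives no direct guide. Compound 4 is therefore expected to show a number 6 percentage points higher from compound 1 to compound 4 (within the scatter), a step within the scatter. The estimate for compound 4 in this assay is 20%, with a range from 5% to 40%.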

Compound 4, a percentage reported as inhibition, at one concentration (the size of the read-out at that concentration, not a potency): 25%
Estimate against measurement, compound 4: 5 percentage points below; the measured number falls inside the stated range.
By their numbers in this assay, from the lowest: compounds 1, 3 and 4 (each within the scatter of the next, the first and the last beyond it); then compound 2.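

In this assay, for the compounds shown here, replacing 4-fluorophenyl with 2-chlorophenyl on the amine nitrogen gives a number 11 percentage points higher from compound 1 to compound 4 (beyond the scatter), the first change between halogen-bearing phenyl groups here to lie beyond the scatter, while 2-chlorophenyl in place of 4-iodophenyl gives a number 1 percentage points higher from compound 3 to compound 4 (within the scatter), so those two groups cannot be told apart. The 1-phenylethyl group stays apart from this new aryl group as well, with a number 17 percentage points lower from compound 2 to compound 4 (beyond the scatter) when 2-chlorophenyl takes its place. No evidence is at hand on what lies behind these differences.

Going from 4-fluorophenyl to 2-chlorophenyl alters both the halogen and where it sits on the ring, and the compounds shown do not separate the two. As far as these compounds go, how a benzyl group or a pyridine ring on this amine nitrogen would compare with the 1-phenylethyl group also remains open.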